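This account rests on a few compounds, and the source may have more. Where it says the series, first, only, none or still open, it means among the compounds named here.

Measured in a functional assay on LNCaP cells (Homo sapiens) for cytotoxicity, read by MTT assay, with a stated time of 72 h; on this read-out lower numbers stand for stronger inhibition and higher numbers for weaker inhibition:
Compound 1 `CC(C)(C)OC(=O)N1CCN(c2c(C(=O)NCc3ccc(F)cc3)nc(Br)c3cccnc23)CC1`: > 10000 nM (a limit of the assay)
Compound 2 `Nc1ccc(Nc2c(C(=O)NCc3ccc(F)cc3)nc(Br)c3cccnc23)cc1`: 7000 nM
Compound 3 `CN(C)CCCNc1c(C(=O)NCc2ccc(F)cc2)nc(Br)c2cccnc12`: 8000 nM

Only two of these results are true numbers, and they cannot be told apart: a 1.1-fold higher number from compound 2 to compound 3 (0.06 log units; within the scatter). Compound 3 therefore stands level with compound 2. Compound 1 reports only a limit, > 10000 nM, and no number. That limit is part of the picture here: the limit of > 10000 nM in this assay, at which 1 of the 3 values shown sits.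

Compound 4 `COC(=O)CNc1c(C(=O)NCc2ccc(F)cc2)nc(Br)c2cccnc12` keeps the shared core and alters only the chain on the nitrogen. Methoxycarbonyl comes in place of 2-(dimethylamino)ethyl on a saturated chain carbon bound to a nitrogen on an aromatic ring: methoxycarbonyl in place of 2-(dimethylamino)ethyl on a saturated chain carbon bound to a nitrogen on an aromatic ring. Read one bond further out, 3-(dimethylamino)propyl gives way to (methoxycarbonyl)methyl.

Among the measured compounds shown here, one measured step bears on this, a change at the same nitrogen, and it stayed small: a 1.1-fold higher number from compound 2 to compound 3 (0.06 log units; within the scatter). For the measured compounds named here, no measured compound carries a methoxycarbonyl group, so this evidence is thin. In this assay, no step beyond the scatter is expected. Compound 3 already gives 8000 nM. Any upward drift from there could be expected to end in a reported limit rather than a number. The estimated change is a 1.1-fold higher number from compound 3 to compound 4 (0.05 log units; within the scatter). For compound 4 the expected value is 9000 nM, with an estimated range of 4000 nM to 20000 nM.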

Compound 4, half-maximal inhibitory concentration: 5000 nM
Estimate against measurement, compound 4: 1.8-fold (0.26 log units) above; the range from low to high includes it.
By their numbers in this assay, from the lowest: compounds 4, 2 and 3 (each within the scatter of the next). At a limit, above all of these: compound 1.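

Among the compounds shown here, the new step adds a kind of change the earlier compounds did not cover: in this assay, methoxycarbonyl in place of 2-(dimethylamino)ethyl on a saturated chain carbon bound to a nitrogen on an aromatic ring gives a 1.6-fold lower number from compound 3 to compound 4 (0.20 log units; within the scatter). Set against the 4-aminophenyl group on the same nitrogen, (methoxycarbonyl)methyl gives a 1.4-fold lower number from compound 2 to compound 4 (0.15 log units; within the scatter), so the three true numbers at this position cannot be told apart, even though the chain ending now has a carbonyl and no dimethylamino group. Compound 1 remains the only entry that is a limit and not a number: the limit of > 10000 nM in this assay, at which 1 of the 4 values shown sits.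

The compounds shown leave open whether any group on this nitrogen can produce a step beyond the scatter, as none of the steps among the three true numbers does. A carboxylic acid in place of methoxycarbonyl, a primary amide at the same carbon, or a longer chain ending in either group would test whether this flat picture holds beyond the three groups compared here.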